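Isopropenyl for isopropyl in the quinolone series

The source may report more compounds than this note shows. Statements on the series, on what has been measured and on what is new or still open speak of the compounds shown alone.

Within the data shown here, compound 2 `Cc1c(C(=O)Nc2ccc(Oc3ncnc4[nH]cc(-c5ccccc5)c34)c(F)c2)c(=O)c2cc(C(C)C)ccc2n1C` holds the lower of the two numbers measured so far in an assay on isolated protein for inhibition of tyrosine-protein kinase receptor UFO (Homo sapiens), read by FRET and Z'-LYTE, with a stated time of 1.5 h; a higher number here means a weaker inhibitor, a lower number a stronger inhibitor; compound 2 gives 26 nM, while compound 1 `Cc1c(C(=O)Nc2ccc(Oc3ncnc4[nH]cc(-c5ccccc5)c34)c(F)c2)c(=O)c2cc(Cl)ccc2n1C` gives 1890 nM. Among the measured compounds shown here, the one measured step, a 73-fold lower number from compound 1 to compound 2 (1.86 log units; beyond the scatter), is the only point of reference for this change.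

Compound 3 `C=C(C)c1ccc2c(c1)c(=O)c(C(=O)Nc1ccc(Oc3ncnc4[nH]cc(-c5ccccc5)c34)c(F)c1)c(C)n2C` is not yet measured. It differs from compound 2 by 1-methylethenyl in place of isopropyl on an aromatic carbon. The group that leaves and the group that enters have the same count of heavy atoms, and the only counted difference is the double bond outside aromatic rings that enters.

The measured step concerns a different exchange at the same site, chloro to isopropyl, and says nothing direct about isopropyl against 1-methylethenyl. For the measured compounds named here, with no step that bears closely on it, the expectation is a small shift, if any, and one that may well lie within the scatter. Compound 3 is therefore expected to give about 45 nM in this assay, between 15 nM and 140 nM, which would correspond to an estimated step of a 1.7-fold higher number from compound 2 to compound 3 (0.24 log units; within the scatter).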

Compound 3, half-maximal inhibitory concentration: 170 nM
Beside the measured number, compound 3's estimate is 3.8-fold (0.58 log units) below it, outside the stated range (above it).
By their numbers in this assay, from the lowest: compound 2; then compound 3; then compound 1.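

In this assay this aromatic carbon proves sensitive to more than the size of the group: the two groups have the same count of heavy atoms, yet the step of a 6.5-fold higher number from compound 2 to compound 3 (0.82 log units; beyond the scatter) is beyond the scatter, and the one counted difference is the double bond outside aromatic rings that enters with 1-methylethenyl. Measured against chloro, 1-methylethenyl still gives a clear gain, with the step of an 11-fold lower number from compound 1 to compound 3 (1.05 log units; beyond the scatter) also beyond the scatter, so the three groups now form an order at this site, with isopropyl giving the lowest number, then 1-methylethenyl, then chloro. Nothing available accounts for the gap between isopropyl and 1-methylethenyl.

The compounds shown leave open how cyclopropyl or tert-butyl would read at this aromatic carbon, and whether methoxy or an amine would fall nearer to compound 2 or to compound 1. They also leave open whether the order of these three groups would hold with any change elsewhere on the shared core, since the rest of the structure is the same in all three compounds.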